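A few compounds are considered here, and "the series" means these few. Any claim that something is new, unique, unknown or untested is made for them only; others in the source may bear on it.

In a functional assay on L02 cells (Homo sapiens) for inhibition, read by MTT assay, with a stated time of 48 h (on this read-out higher numbers stand for weaker inhibition and lower numbers for stronger inhibition), compound 1 (`COc1ccc(CNC(=O)/C=C/c2coc3cc(O)ccc3c2=O)cc1`) gives > 200000 nM as a limit of the assay and not as a number. Compound 2 (`COc1ccc2c(=O)c(/C=C/C(=O)Nc3ccccc3)coc2c1`) gives > 200000 nM and this too is a limit. Going by the values given here, compound 2 therefore has no exact value, and no step between two measured compounds is available as a guide.

Compound 3 (`COc1ccc2c(=O)c(/C=C/C(=O)NCc3ccc(F)cc3)coc2c1`) keeps the core of compound 2 and changes one group, with 4-fluorobenzyl in place of phenyl on an amide-type nitrogen. Among the compounds with values here, the only evidence to go on is the limit of > 200000 nM in this assay, at which 2 of the 2 values shown sit, and it gives no sign that changing this group moves the result in either direction. No change beyond the usual scatter is therefore expected in this assay and another limit is the most likely report. The expected size of the change (a number no higher from compound 2 to compound 3 (the limit leaves the size open)) is correspondingly small. If a number is obtained, compound 3 is expected to fall near 200000 nM with an estimated range from 80000 nM to 400000 nM as the likely span.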

Compound 3, half-maximal inhibitory concentration: > 200000 nM
Compound 3 ended at the assay's limit; the forecaster's own chance of this, stated with the estimate: 75%; the middle value lies on the limit itself.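

In this assay, compound 2 and compound 3 each give a limit and not a number, and no step can be read between them. From the compounds shown here alone, whether 4-fluorobenzyl in place of phenyl has any effect therefore stays unknown. The compounds shown leave open whether any change to their structures would give a readable number in this assay.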